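Extending the Linker in a Cyanoimino Imidazolidinone Series

The compounds below may be only part of what the source reports. "The series", "measured", "known", "first", "only" and "open" are said of these compounds alone.

The measured compounds so far:
Compound 1, `N#C/N=C1\N(CCCCCOc2ccc(Cl)cc2)C(=O)CN1c1ccncc1`, gives 5360 nM in a functional assay on MCF7 cells (Homo sapiens) for cytotoxicity; on this read-out lower numbers stand for stronger inhibition and higher numbers for weaker inhibition.
Compound 2, `N#C/N=C1\N(CCCCCCOc2ccc(Cl)cc2)C(=O)CN1c1ccncc1`, gives 443 nM in this assay.
Compound 3, `N#C/N=C1\N(CCCCCOc2ccc(Cl)cc2)C(=O)C(c2ccccc2)N1c1ccncc1`, gives 1000 nM in this assay.

Compound 4, `N#C/N=C1\N(CCCCCCOc2ccc(Cl)cc2)C(=O)C(c2ccccc2)N1c1ccncc1`, has not yet been measured. It stands to compound 3 as compound 2 stands to compound 1: the change (4-chlorophenoxy)methyl in place of 4-chlorophenoxy on a saturated chain carbon, five bonds along the chain from an amide-type nitrogen in a ring is the same as (4-chlorophenoxy)methyl in place of 4-chlorophenoxy on a saturated chain carbon, five bonds along the chain from an amide-type nitrogen in a ring, and the place is described in identical words for both pairs. That change has been seen once already, and it gave a 12-fold lower number from compound 1 to compound 2 (1.08 log units; beyond the scatter).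

The two pairs rest on different cores. Compound 3 and compound 4 carry the change phenyl in place of hydrogen on a saturated ring carbon relative to compound 1 and compound 2. On its own, that change gave a 5.4-fold lower number from compound 1 to compound 3 (0.73 log units; beyond the scatter).

From the compounds shown here alone, whether the two changes add up fully is unknown from three compounds alone. For the measured compounds named here, the expectation for compound 4 is therefore a step of about the size seen before, tempered somewhat because the only comparison available, a 12-fold lower number from compound 1 to compound 2 (1.08 log units; beyond the scatter), comes from a core without the phenyl. On that basis compound 4 is expected to show an 8.3-fold lower number from compound 3 to compound 4 (0.92 log units; beyond the scatter) in this assay. The estimate for compound 4 in this assay is 120 nM, with a likely range from 40 nM to 400 nM.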

Compound 4, half-maximal inhibitory concentration: 1130 nM
For compound 4 the middle estimate is 9.4-fold (0.97 log units) below the measured one; the whole stated range lies below it.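

In this assay, (4-chlorophenoxy)methyl in place of 4-chlorophenoxy gave a 1.1-fold higher number from compound 3 to compound 4 (0.05 log units; within the scatter), so the large gain seen on the core of compound 1 did not carry over to the core bearing the phenyl: the same change on two cores in this assay, a 12-fold lower number (1.08 log units; beyond the scatter) from compound 1 to compound 2 and a 1.1-fold higher number (0.05 log units; within the scatter) from compound 3 to compound 4, 14-fold (1.14 log units) apart, beyond the scatter of two such steps

The reverse comparison tells the same story, since phenyl in place of hydrogen on a saturated ring carbon gave a 2.6-fold higher number from compound 2 to compound 4 (0.41 log units; beyond the scatter), a step in the opposite direction from the one seen with the shorter chain: the same change on two cores in this assay, a 5.4-fold lower number (0.73 log units; beyond the scatter) from compound 1 to compound 3 and a 2.6-fold higher number (0.41 log units; beyond the scatter) from compound 2 to compound 4, 14-fold (1.14 log units) apart, beyond the scatter of two such steps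

Across these four compounds the two changes therefore do not add up, and the effect of each depends on whether the other is present, but two cores cannot show why this happens or how the chain change would behave on any further core.

The compounds shown leave open whether a still longer chain would lower the number on either core. They also leave open whether a smaller group such as methyl in place of the phenyl, or fluorine in place of the chlorine, would show the same dependence between the two changes.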